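A few compounds are considered here, and "the series" means these few. Any claim that something is new, unique, unknown or untested is made for them only; others in the source may bear on it.

Compounds measured in an ADME assay for permeability, using PAMPA, with a stated time of 30 min, at pH 7.4; a lower number here means that the compound crosses the layer more slowly, a higher number that the compound crosses the layer faster:
compound 1 `COc1cccc(CNCCCNc2ccnc3cc(C4CCCCC4)ccc23)c1O` gives 23 10^-6 cm/s
compound 2 `CCC(CC)c1ccc2c(NCCCNCc3cccc(OC)c3O)ccnc2c1` gives 23 10^-6 cm/s
compound 3 `COc1cccc(CNCCCNc2ccnc3cc(-c4ccc(C(F)(F)F)cc4)ccc23)c1O` gives 237 10^-6 cm/s

Compound 3 stands highest of the three numbers in this assay; its nearest neighbour is compound 1, and compound 2 sits at the same distance. Among the steps between measured compounds, the replacement on the aromatic carbon of the shared core is the only variable: no change at the digits printed from compound 1 to compound 2 (within the scatter), whereas a 10-fold higher number from compound 1 to compound 3 (1.01 log units; beyond the scatter) and a 10-fold higher number from compound 2 to compound 3 (1.01 log units; beyond the scatter). Both steps from a saturated group to an aryl group are large and point the same way, while the step between the two saturated groups stays flat.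

Compound 4 `COc1cccc(CNCCCNc2ccnc3cc(-c4cccc5ccccc45)ccc23)c1O` differs from compound 3 as follows: naphthalen-1-yl in place of 4-(trifluoromethyl)phenyl on an aromatic carbon. Among the measured compounds shown here, this change exchanges one aryl group for another at the same place, so the two large steps into compound 3 bear on it only indirectly: they show the aryl-bearing compound 3 far above the two saturated compounds, but no measured pair compares two aryl groups. The step expected for compound 4 is therefore a 1.6-fold lower number from compound 3 to compound 4 (0.20 log units; within the scatter), at most a modest change. Compound 4 is estimated at 150 10^-6 cm/s in this assay, with a range from 50 10^-6 cm/s to 400 10^-6 cm/s.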

Compound 4, apparent permeability: 237 10^-6 cm/s
Estimate against measurement, compound 4: 1.6-fold (0.20 log units) below; the measured number falls inside the stated range.
By their numbers in this assay, from the lowest: compounds 1 and 2 (each within the scatter of the next); then compounds 3 and 4 (each within the scatter of the next).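

In this assay, a second aryl group at this position matches the first: naphthalen-1-yl in place of 4-(trifluoromethyl)phenyl leaves the number unchanged (no change at the digits printed from compound 3 to compound 4 (within the scatter)), although the two groups differ in their atoms and in their count of rings. The large rise is therefore no longer tied to a single group, since naphthalen-1-yl gives the same size of step from either saturated group (a 10-fold higher number from compound 2 to compound 4 (1.01 log units; beyond the scatter); a 10-fold higher number from compound 1 to compound 4 (1.01 log units; beyond the scatter)), and among these four compounds the two aryl-bearing ones stand apart from the two with saturated groups, with none going against that split. Nothing among the data shown accounts for this separation or for the match between the two aryl groups.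

As far as these compounds go, both aryl groups here are aromatic rings of carbon only and carry no amine or carboxylic acid, so it remains open whether a pyridine ring, or an aryl ring bearing either of those groups, would stand with compound 3 and compound 4. From the compounds shown here alone, it is also open where a small group such as methyl, or a plain hydrogen at this place, would fall relative to these two sets.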